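This account rests on a few compounds, and the source may have more. Where it says the series, first, only, none or still open, it means among the compounds named here.

Measured compounds:
compound 1 `CC(C)(C)c1ccc(-n2nc(-c3ccc(C(F)(F)F)cc3O)nc2-c2ccccc2O)cc1` gives 77.8% in a functional assay on PC-12 cells (Rattus norvegicus) for cytotoxicity, read by MTT assay, with stated times of 2 h and 24 h, tested at 5 uM; a lower number here means a weaker effect, a higher number a stronger effect of the compound at the concentration tested.
compound 2 `Oc1cc(C(F)(F)F)ccc1-c1nc(-c2ccccc2O)n(-c2ccc(F)cc2)n1` gives 86.7% in this assay.
compound 3 `Oc1cc(C(F)(F)F)ccc1-c1nc(-c2ccccc2O)n(-c2ccccc2F)n1` gives 86.6% in this assay.

Compound 3 sits within the scatter of both others: the step of a number 0.1 percentage points lower from compound 2 to compound 3 (within the scatter) and the step of a number 8.8 percentage points higher from compound 1 to compound 3 (within the scatter) are each inside the usual spread, so no ordering among the three is supported. The same holds for a number 8.9 percentage points higher from compound 1 to compound 2 (within the scatter). Compound 4 `COc1ccccc1-n1nc(-c2ccc(C(F)(F)F)cc2O)nc1-c1ccccc1O` differs from compound 3 by methoxy in place of fluoro on an aromatic carbon. Going by the values given here, no measured step exchanges fluoro for methoxy; the closest bearing steps are the changes on the aromatic nitrogen substituent, all within the scatter. Compound 4 is therefore expected to show no change beyond the scatter in this assay, an estimated step of a number 1.6 percentage points lower from compound 3 to compound 4 (within the scatter). The estimated value for compound 4 in this assay is 85%, with a range from 72% to 96%.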

Compound 4, a percentage reported as activity, at one concentration (the size of the read-out at that concentration, not a potency): 85.6%
For compound 4 the middle estimate is 0.6 percentage points below the measured one; measured number inside the range.
By their numbers in this assay, from the lowest: compounds 1, 4, 3 and 2 (each within the scatter of the next).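

Methoxy in place of fluoro on an aromatic carbon, ortho to a large group, gives the step of a number 1 percentage points lower from compound 3 to compound 4 (within the scatter) in this assay and so adds an oxygen and a hydrogen-bond acceptor at this position without a step beyond the scatter. The steps of a number 1.1 percentage points lower from compound 2 to compound 4 (within the scatter) and a number 7.8 percentage points higher from compound 1 to compound 4 (within the scatter) place 2-methoxyphenyl with the other three aromatic nitrogen substituents, with no separation among the four.

Nothing available here explains why the four values lie together. Going by these compounds, whether an amine or a carboxylic acid at this position would give a step beyond the scatter remains open.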